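Bromo in Place of Hydrogen: Notes on Compound 3

This account rests on a few compounds, and the source may have more. Where it says the series, first, only, none or still open, it means among the compounds named here.

Of the compounds shown here, two of the shared core have numbers so far. Compound 1 `O=C1C=COC(/C=C/c2ccc(C(F)(F)F)cc2)C1` in a functional assay on HT-29 cells (Homo sapiens) for inhibition, read by sulforhodamine B assay, with a stated time of 48 h (a higher number here means a weaker inhibitor of growth, a lower number a stronger inhibitor of growth), gives 33.3 uM. Compound 2 `COc1ccc(C2CC(=O)C=CO2)cc1` gives 203 uM in this assay, the highest of the two numbers, and the gap to compound 1 is beyond the scatter; the two compounds differ in more than one place, so the gap is not taken apart here.

Compound 3 `COc1ccc(C2CC(=O)C(Br)=CO2)cc1` differs from compound 2 in a single place: bromo in place of hydrogen on a double-bonded ring carbon. For the measured compounds named here, no step of this kind has been measured, so nothing measured says how large a change to expect.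

Going by the values given here, the working expectation is that the step from compound 2 to compound 3 lowers the number, a 2.3-fold lower number from compound 2 to compound 3 (0.35 log units; beyond the scatter), by a moderate amount, with a broad range because compound 2 gives 203 uM and no measured pair anchors the direction. Compound 3 is therefore estimated at 90 uM in this assay, with a range from 30 uM to 300 uM.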

Compound 3, concentration for growth inhibition (reported as GI): 69 uM
For compound 3 the middle estimate is 1.3-fold (0.12 log units) above the measured one; the measured number falls inside the stated range.
By their numbers in this assay, from the lowest: compound 1; then compound 3; then compound 2.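

In this assay, bromo in place of hydrogen on a double-bonded ring carbon gives a 2.9-fold lower number from compound 2 to compound 3 (0.47 log units; beyond the scatter), the first single-place step measured in the series. This position, two ring bonds from the ring oxygen, therefore accepts a bromo with a modest gain in growth inhibition rather than a loss, although this rests on one pair only and says nothing yet about a trend. No measurement at hand bears on what lies behind the size or direction of this step.

The compounds shown leave open whether a chloro, a methyl group or an amine on this same carbon would move the number in the same direction. Also open, from the compounds shown here alone, is whether bromo on this carbon gives a comparable step in the setting of compound 1.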